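Carboxyl-bearing replacements for the aryl amide of compound 1

A few compounds are considered here, and "the series" means these few. Any claim that something is new, unique, unknown or untested is made for them only; others in the source may bear on it.

Among the compounds with values here, in an assay on U2OS cells for inhibition of secreted frizzled-related protein 1 (Homo sapiens), read by a luciferase reporter, with a stated time of 18 h (on this read-out higher numbers stand for an effect only at larger amounts of compound and lower numbers for an effect already at smaller amounts), compound 1 `O=C(c1ccc(C(F)(F)F)cc1)N1CCC(NS(=O)(=O)c2cc(S(=O)(=O)c3ccccc3)ccc2C(F)(F)F)CC1` gives 970 nM, the highest of the three numbers known. Compound 2 `O=C(O)c1cccc(S(=O)(=O)N2CCC(NS(=O)(=O)c3cc(S(=O)(=O)c4ccccc4)ccc3C(F)(F)F)CC2)c1` gives 190 nM and compound 3 `O=C(O)c1ccc(N2CCC(NS(=O)(=O)c3cc(S(=O)(=O)c4ccccc4)ccc3C(F)(F)F)CC2)cc1` gives 230 nM; the two carboxyl-bearing analogues are within the scatter of each other, a 1.2-fold higher number from compound 2 to compound 3 (0.08 log units; within the scatter). Compound 4 `O=C(O)CCCC(=O)N1CCC(NS(=O)(=O)c2cc(S(=O)(=O)c3ccccc3)ccc2C(F)(F)F)CC1` differs from compound 1 as follows: 3-carboxypropyl in place of 4-(trifluoromethyl)phenyl on a carbonyl carbon. Within the data shown here, the steps that bear on it, a 5.1-fold lower number from compound 1 to compound 2 (0.71 log units; beyond the scatter) and a 4.2-fold lower number from compound 1 to compound 3 (0.63 log units; beyond the scatter), both bring a carboxyl group onto the amine nitrogen side and both lower the number modestly. Compound 4 also carries a carboxyl, but on a chain with no ring, so a smaller step is expected, a 2.2-fold lower number from compound 1 to compound 4 (0.33 log units; beyond the scatter). Compound 4 is therefore estimated at 450 nM, within 150 nM to 1300 nM.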

Compound 4, half-maximal effective concentration: 570 nM
The estimate for compound 4 lay 1.3-fold (0.10 log units) below the measured number; the measured number falls inside the stated range.
By their numbers in this assay, from the lowest: compounds 2 and 3 (each within the scatter of the next); then compounds 4 and 1 (each within the scatter of the next).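

In this assay, the carboxyl on the 3-carboxypropyl chain does not separate compound 4 from the aryl amide: a 1.7-fold lower number from compound 1 to compound 4 (0.23 log units; within the scatter). The ring-bearing carboxyl analogues do stand apart from it, with a 2.5-fold higher number from compound 3 to compound 4 (0.39 log units; beyond the scatter) and a 3.0-fold higher number from compound 2 to compound 4 (0.48 log units; beyond the scatter), so on this amine nitrogen a carboxyl alone does not account for the lower numbers of compound 2 and compound 3. Nothing available explains this difference.

Still open, going by these compounds, is whether the aromatic ring or the linking group matters more; (4-carboxyphenyl)carbonyl would separate the two. A 3-aminopropyl group in place of 3-carboxypropyl would show what the carboxylic acid itself contributes.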